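Losing one methoxy group: from compound 2 to compound 3

This account rests on a few compounds, and the source may have more. Where it says the series, first, only, none or still open, it means among the compounds named here.

Two compounds sharing one core have numbers in a functional assay on L1210 cells (Mus musculus) for antiproliferative activity, read by sulforhodamine B assay, with a stated time of 48 h (a lower number here means a stronger inhibitor, a higher number a weaker inhibitor), so far. Compound 1 (`Cc1ccc(C)c(NS(=O)(=O)c2ccc(N3CCNC3=O)cc2)c1`) gives 81 nM there, and compound 2 (`COc1cc(NS(=O)(=O)c2ccc(N3CCNC3=O)cc2)cc(OC)c1`) gives 110 nM on the same read-out. These two values lie within the scatter of each other, so compound 2 stands level with compound 1 on the evidence available.

Compound 3 (`COc1cccc(NS(=O)(=O)c2ccc(N3CCNC3=O)cc2)c1`) has not yet been measured in this assay and differs from compound 2 by one change: hydrogen in place of methoxy on an aromatic carbon. For the measured compounds named here, no measured pair in this small set shows what such a change does, so the only anchor is compound 2 at 110 nM as the closest measured structure. The expectation is a modest move toward a weaker inhibitor, an estimated 2.3-fold higher number from compound 2 to compound 3 (0.36 log units; beyond the scatter) that may not lie far beyond the scatter. For compound 3 the estimated value is 250 nM with an expected range that runs from 80 nM to 800 nM at the far end.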

Compound 3, half-maximal inhibitory concentration: 240 nM
Compound 3: the middle estimate sits 1.0-fold (0.02 log units) above what was measured, within the range that was stated.
By their numbers in this assay, from the lowest: compounds 1 and 2 (each within the scatter of the next); then compound 3.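

In this assay, for the compounds shown here, hydrogen in place of methoxy gives a 2.2-fold higher number from compound 2 to compound 3 (0.34 log units; beyond the scatter), the first single-group step in this set, and it shows that this place on the ring, meta to a large group and meta to a methoxy group, is not indifferent to what it carries. Going by these compounds alone, the second step, 3-methoxyphenyl in place of 2,5-dimethylphenyl on a sulfonamide nitrogen, gives a 3.0-fold higher number from compound 1 to compound 3 (0.47 log units; beyond the scatter) and so sets compound 3 apart from a pair that stood level with each other, although both steps are modest in size and the single remaining methoxy group does not hold the number where the two-methoxy ring had it. Nothing given here speaks to what lies behind either step.

The compounds shown leave open whether a hydroxy group, an amine or a longer chain such as ethoxy at this place would track with methoxy or with hydrogen. Within the data shown here, they also leave open whether the loss of a methoxy group carries the same weight on a ring with a different substitution, as only one pair holds this change so far.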